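A few compounds are considered here, and "the series" means these few. Any claim that something is new, unique, unknown or untested is made for them only; others in the source may bear on it.

So far, two compounds have been measured in a functional assay on HCT-116 cells (Homo sapiens) for cytotoxicity, read by MTT assay, with a stated time of 72 h; a higher number here means a weaker inhibitor, a lower number a stronger inhibitor. Compound 1 (`CN1C/C(=C\c2ccccc2F)C(=O)/C(=C/c2ccccc2F)C1`) gives 1300 nM, and compound 2 (`CN1C/C(=C\c2ccc(F)c(F)c2)C(=O)/C(=C/c2ccc(F)c(F)c2)C1`) gives 510 nM. Compound 1 therefore has the higher of the two numbers, which makes it the weaker inhibitor of the pair, and the gap is larger than the usual scatter of repeated measurements. Compound 3 (`CCN1C/C(=C\c2ccccc2F)C(=O)/C(=C/c2ccccc2F)C1`) differs from compound 1 in one place: methyl in place of hydrogen on a saturated chain carbon bound to an amine nitrogen in a ring. In words, this is methyl in place of hydrogen on a saturated chain carbon bound to an amine nitrogen in a ring, and the same difference can be read as methyl to ethyl. For the measured compounds named here, no measured pair here shows what this change does in this assay, and the two measured values offer no direct guide to its direction. A small change of this kind is expected to produce no step beyond the scatter, leaving the result close to compound 1 at 1300 nM. The estimated step is a 1.1-fold lower number from compound 1 to compound 3 (0.03 log units; within the scatter). For compound 3, the expected value is 1200 nM, with an estimated range from 500 nM to 2800 nM.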

Compound 3, half-maximal inhibitory concentration: 1800 nM
The estimate for compound 3 lay 1.5-fold (0.18 log units) below the measured number; the range from low to high includes it.
By their numbers in this assay, from the lowest: compound 2; then compounds 1 and 3 (each within the scatter of the next).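

In this assay, methyl in place of hydrogen on a saturated chain carbon bound to an amine nitrogen in a ring, the change that can also be read as methyl to ethyl, gives a 1.4-fold higher number from compound 1 to compound 3 (0.14 log units; within the scatter). For the compounds shown here, this step lies within the usual scatter of repeated measurements, so this is the first one-place comparison at this position, and it shows no difference that can be told apart from that scatter. No measurement among the data shown bears on why the result came out this way.

This single change is a narrow test of the position, and the compounds shown leave open how a longer chain such as propyl, a benzyl group or a hydrogen in place of the methyl of compound 1 would behave here. From the compounds shown here alone, it also remains open whether methyl to ethyl would stay within the scatter on compound 2, which carries a different arrangement of fluorine on its rings.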